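A few compounds are considered here, and "the series" means these few. Any claim that something is new, unique, unknown or untested is made for them only; others in the source may bear on it.

Working notes on the series in a functional assay on HEK293 cells for agonist activity at Thyrotropin receptor (Homo sapiens), read by cAMP accumulation; a lower number here means a smaller maximal response, a higher number a larger maximal response. Compound 1 `COc1cccc(-c2nc(SC)nc3sc(C(=O)NCC#N)c(N)c23)c1` gives 3.6% in this assay, and compound 2 `COc1cccc(-c2nc(SC)nc3sc(C(=O)NN)c(N)c23)c1` gives 6.1% in this assay. Within the data shown here, the one step measured so far, a number 2.5 percentage points higher from compound 1 to compound 2 (within the scatter), puts compound 2 at the upper end of the two numbers, yet the gap is within the scatter, so the two compounds cannot be told apart and both sit near the floor of the read-out.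

Compound 3 `CCNC(=O)c1sc2nc(SC)nc(-c3cccc(OC)c3)c2c1N` differs from compound 2 by ethyl in place of amino on an amide-type nitrogen; cut one bond further out, the same difference reads aminocarbamoyl to ethylcarbamoyl. Among the measured compounds shown here, the only step that bears on it is the one from compound 1 to compound 2, which likewise altered the substituent on the amide-type nitrogen and stayed within the scatter. With two low numbers and one flat step as the whole basis, no change beyond the scatter is expected for compound 3 in this assay: the step is estimated as a number 1.1 percentage points lower from compound 2 to compound 3 (within the scatter). Compound 3 is thus expected at 5%, with a range from 0% to 15%.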

Compound 3, largest response reached (reported as efficacy), in percent of the reference or control that the assay uses: 2.3%
Compound 3: middle estimate off by 2.7 percentage points, on the high side, within the range that was stated.
By their numbers in this assay, from the lowest: compounds 3, 1 and 2 (each within the scatter of the next).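

In this assay the step of a number 3.8 percentage points lower from compound 2 to compound 3 (within the scatter) replaces amino with ethyl on the amide-type nitrogen, and the step of a number 1.3 percentage points lower from compound 1 to compound 3 (within the scatter) places methyl where cyano stood on the saturated chain carbon bound to that nitrogen. Amino, cyanomethyl and ethyl therefore cannot be told apart at this position, even though ethyl carries none of the hydrogen-bond donors or acceptors counted on amino, and the series now has an all-carbon substituent that stays within the scatter of the other two. The compounds shown offer no independent data that could explain this flat read-out. 

Still open, going by these compounds, is whether any substituent on this nitrogen can lift the maximal response clear of the scatter, for instance a longer chain, a benzyl group, a carboxylic acid or a chain ending in an amine. Also open, on these data alone, is whether the nitrogen substituent would matter at all with changes elsewhere on the shared core, since all three compounds differ only at this one place.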